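Swapping a furan for a thiophene on the amine arm

The source may report more compounds than this note shows. Statements on the series, on what has been measured and on what is new or still open speak of the compounds shown alone.

Compound 2 `Nc1nc(NCc2ccco2)nc2sc(-c3ccco3)nc12` gives 82 nM in a functional assay on CHO cells for agonist activity at adenosine receptor A2b (Homo sapiens), read by scintillation counting and cAMP accumulation, with a stated time of 150 min, in the presence of a further agent that is not named here; a higher number here means a weaker inhibitor, a lower number a stronger inhibitor. Compound 1 `Cc1ccc(-c2nc3c(N)nc(NCc4cccs4)nc3s2)o1` gives 91 nM in this assay, and the two numbers lie within the usual scatter of each other. Compound 3 `Nc1nc(NCc2ccsc2)nc2sc(-c3ccco3)nc12` differs from compound 2 by thiophen-3-yl in place of furan-2-yl on a saturated chain carbon bound to a nitrogen on an aromatic ring. Compound 1 already carries a thiophene at this place and shows a number close to that of compound 2, so no step beyond the scatter is expected from compound 2 to compound 3, that is a 1.2-fold higher number from compound 2 to compound 3 (0.09 log units; within the scatter). Compound 3 is therefore estimated at 100 nM, with a range from 40 nM to 250 nM.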

Compound 3, half-maximal inhibitory concentration: 8.96 nM
Compound 3: middle estimate off by 11-fold (1.05 log units), on the high side, and the stated range ends above it.
By their numbers in this assay, from the lowest: compound 3; then compounds 2 and 1 (each within the scatter of the next).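

In this assay, thiophen-3-yl in place of furan-2-yl on a saturated chain carbon bound to a nitrogen on an aromatic ring gives a 9.2-fold lower number from compound 2 to compound 3 (0.96 log units; beyond the scatter) and this lies beyond the scatter. This place therefore responds to an exchange of one five-membered aromatic ring for another, even with the same heavy-atom, donor and acceptor counts. Nothing measured here accounts for the step. Still open, as far as these compounds go, is whether the step follows the sulfur or the ring's point of attachment, which thiophen-2-yl and furan-3-yl on the core of compound 2 would separate. How a phenyl ring would behave at this place is also unknown.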